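The source may hold more compounds than are shown below. What is called first, only, known or untested is meant among the compounds shown, and "the series" means these compounds.

Of the compounds shown here, three built on a shared core have been tested in a functional assay on cells (T-cell, Homo sapiens) for inhibition; on this read-out higher numbers stand for weaker inhibition and lower numbers for stronger inhibition. Compound 1 `COc1ccc(-c2cnc3nc(N)nc(N4CCN(Cc5c(Cl)cccc5Cl)CC4)c3n2)cc1OC` gives 7600 nM, compound 2 `Cc1ccc(-c2cnc3nc(N)nc(OC(C)C)c3n2)cc1C` gives 10000 nM, and compound 3 `COc1ccc(-c2cnc3nc(N)nc(N4CCN(Cc5ccccc5)CC4)c3n2)cc1OC` gives 900 nM, the lowest of the three numbers. Within the data shown here, the only single-point change among them, an 8.4-fold lower number from compound 1 to compound 3 (0.93 log units; beyond the scatter), shows that the group on the amine nitrogen in the ring can shift the result by a modest amount. Compound 4 `COc1ccc(-c2cnc3nc(N)nc(N4CCN(C(=O)Nc5cccc(C)c5)CC4)c3n2)cc1OC` differs from compound 3 by (3-methylphenyl)carbamoyl in place of benzyl on an amine nitrogen in a ring. Among the measured compounds shown here, this change sits at the same place, but no measured step exchanges a benzyl for a (3-methylphenyl)carbamoyl, so the direction is uncertain. For compound 4 a step of a 2.2-fold higher number from compound 3 to compound 4 (0.35 log units; beyond the scatter) toward a somewhat higher number is expected, with an estimate of 2000 nM ranging from 400 nM to 10000 nM.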

Compound 4, half-maximal inhibitory concentration: 7 nM
Estimate against measurement, compound 4: 290-fold (2.46 log units) above; measured number outside the range, below it.
By their numbers in this assay, from the lowest: compound 4; then compound 3; then compounds 1 and 2 (each within the scatter of the next).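

Replacing benzyl with (3-methylphenyl)carbamoyl gives a 130-fold lower number from compound 3 to compound 4 (2.11 log units; beyond the scatter) in this assay, and replacing 2,6-dichlorobenzyl with the same group gives a 1100-fold lower number from compound 1 to compound 4 (3.04 log units; beyond the scatter) on that amine nitrogen, so this position can move the result far more than the change between the two benzyl groups showed. The entering group brings a hydrogen-bond donor and acceptor that benzyl lacks, but no measurement here explains the gain. Still open, from the compounds shown here alone, is whether the gain needs the methyl group or the aromatic ring at all; a plain phenylcarbamoyl or an acetyl group on this nitrogen would help separate these parts.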